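Bromo to nitro on the core of compound 1

The source may hold more compounds than are shown below. What is called first, only, known or untested is meant among the compounds shown, and "the series" means these compounds.

Measured compounds:
- compound 1 `O=C(c1ccccc1)N1N=C(c2cccs2)CC1c1ccc(Br)cc1` with > 300000 nM
- compound 2 `CN1CCN(c2cc(-c3ccc(C(C)(C)C)cc3)c3ccccc3n2)CC1` with 110000 nM

In a functional assay on BHK-21 cells (Mesocricetus auratus) for cytotoxicity, read by MTT assay (a higher number here means that more compound is tolerated, a lower number that less compound is tolerated), compound 1 gives > 300000 nM as a limit of the assay and not a number. Compound 2 gives a true number there (110000 nM) but has a different structure. Compound 3 `O=C(c1ccccc1)N1N=C(c2cccs2)CC1c1ccc([N+](=O)[O-])cc1` keeps the core of compound 1 and carries nitro in place of bromo on an aromatic carbon. For the measured compounds named here, no measured step covers this change, and no shift beyond the scatter is expected in either direction. The expected change is a number no higher from compound 1 to compound 3 (the limit leaves the size open) (an estimate only). For compound 3 the estimated value is 300000 nM (range 120000 nM to 600000 nM).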

Compound 3, half-maximal cytotoxic concentration: > 300000 nM
Compound 3 ended at the assay's limit; the forecaster's own chance of this, stated with the estimate: 60%; the middle value sits exactly at the limit.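

In this assay, compound 1 and compound 3 both stand at a limit of the assay and not at a number, so no step can be read between them: the limit of > 300000 nM in this assay, at which 2 of the 3 values shown sit.

The compounds shown leave open whether nitro in place of bromo on an aromatic carbon changes how much compound is tolerated.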